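The source may report more compounds than this note shows. Statements on the series, on what has been measured and on what is new or still open speak of the compounds shown alone.

Compound 1 `C/C(=C\c1cc(-c2ccccc2)cs1)C(N)=O` gives in a functional assay on BGC-823 cells (Homo sapiens) for cytotoxicity, read by CCK-8 assay, with a stated time of 24 h (a higher number here means a weaker inhibitor, a lower number a stronger inhibitor), the value > 50000 nM, which is a limit of the assay. Compound 2 `C/C(=C\c1cc(-c2ccc(F)cc2)cs1)C(N)=O` gives in this assay the value > 50000 nM, also a limit. Compound 3 `C/C(=C\c1cc(-c2ccc([N+](=O)[O-])cc2)cs1)C(N)=O` gives in this assay the value > 50000 nM, again a limit.

Compound 3 thus stands at the same limit as the other two: the limit of > 50000 nM in this assay, at which 3 of the 3 values shown sit. The next change, (trifluoromethyl in place of nitro on an aromatic carbon), leads to compound 4 `C/C(=C\c1cc(-c2ccc(C(F)(F)F)cc2)cs1)C(N)=O`. The steps measured so far, a step that the two limits leave unreadable from compound 1 to compound 2, a step that the two limits leave unreadable from compound 1 to compound 3 and a step that the two limits leave unreadable from compound 2 to compound 3, cannot be read in size or direction, so no finite step can be expected from them. The step from compound 3 to compound 4 is therefore expected to be a step that the limit leaves unreadable from compound 3 to compound 4, most likely ending at the limit again. For compound 4 in this assay the estimate is 60000 nM, with a range from 20000 nM to 200000 nM.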

Compound 4, half-maximal inhibitory concentration: > 50000 nM
Compound 4: only a limit was reported; the forecaster's own chance of this, stated with the estimate: 85%; the middle value lies beyond the limit too.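

No step can be read among compound 1, compound 2, compound 3 and compound 4, since all sit at one limit of this assay: the limit of > 50000 nM in this assay, at which 4 of the 4 values shown sit.

As far as these compounds go, whether any substituent on the outer aromatic ring changes cytotoxicity remains open, as does the true potency of each compound.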